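Aryl urea in place of tolyl on the piperazine nitrogen

A few compounds are considered here, and "the series" means these few. Any claim that something is new, unique, unknown or untested is made for them only; others in the source may bear on it.

Among the three measured analogues, compound 3 `COc1ccc(-c2cnc3nc(N)nc(N4CCN(c5ccc(C)cc5)CC4)c3n2)cc1OC` stands second highest: in a functional assay on cells (T-cell, Homo sapiens) for inhibition (on this read-out lower numbers stand for stronger inhibition and higher numbers for weaker inhibition), compound 3 gives 300 nM, while compound 1 `COc1ccc(-c2cnc3nc(N)nc(N4CCN(C(=O)NCc5ccccc5)CC4)c3n2)cc1OC` gives 18 nM and compound 2 `COc1ccc(-c2cnc3nc(N)nc(N4CCN(Cc5ccccc5F)CC4)c3n2)cc1OC` gives 700 nM. Compound 4 `COc1ccc(-c2cnc3nc(N)nc(N4CCN(C(=O)Nc5ccc(C#N)cc5)CC4)c3n2)cc1OC` differs from compound 3 only by (4-cyanophenyl)carbamoyl in place of 4-methylphenyl on an amine nitrogen in a ring. The bearing step is a 17-fold higher number from compound 1 to compound 3 (1.22 log units; beyond the scatter), which shows that removing the carbamoyl linker cost much; a 39-fold higher number from compound 1 to compound 2 (1.59 log units; beyond the scatter) points the same way, and a 2.3-fold lower number from compound 2 to compound 3 (0.37 log units; beyond the scatter) is modest. Restoring a carbamoyl group, now on an aryl rather than a benzyl nitrogen, is therefore expected to bring a lower number, a 7.5-fold lower number from compound 3 to compound 4 (0.88 log units; beyond the scatter), though short of compound 1. Compound 4 is estimated at 40 nM, within 10 nM to 160 nM.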

Compound 4, half-maximal inhibitory concentration: 74 nM
Estimate against measurement, compound 4: 1.9-fold (0.27 log units) below; the measured number falls inside the stated range.
By their numbers in this assay, from the lowest: compound 1; then compound 4; then compound 3; then compound 2.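

In this assay, a carbamoyl group on the amine nitrogen in the ring lowers the number from the directly attached aryl (a 4.1-fold lower number from compound 3 to compound 4 (0.61 log units; beyond the scatter)) and from the 2-fluorobenzyl group (a 9.5-fold lower number from compound 2 to compound 4 (0.98 log units; beyond the scatter)). The carbamoyl link therefore keeps much of its benefit with an aryl rather than a benzyl on its amide-type nitrogen, though 4-cyanophenyl in place of benzyl still raises the number (a 4.1-fold higher number from compound 1 to compound 4 (0.61 log units; beyond the scatter)). Nothing available explains these steps.

From the compounds shown here alone, compound 4 changes both the nitrile and the methylene link at once, so their separate shares remain open. A plain phenyl or a 4-cyanobenzyl on the same nitrogen would separate them.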